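A few compounds are considered here, and "the series" means these few. Any claim that something is new, unique, unknown or untested is made for them only; others in the source may bear on it.

Measured so far:
Compound 1, `O=C(Nc1ccc(Sc2nc3ccccc3s2)c(Cl)c1)c1cc(Br)cc(Br)c1O`: in an assay on isolated protein for inhibition of thiosulfate sulfurtransferase (Homo sapiens), with a stated time of 60 min, in the absence of a further agent (on this read-out higher numbers stand for weaker inhibition and lower numbers for stronger inhibition), compound 1 gives > 100000 nM, which is a limit of this assay and not a number.
Compound 2, `COc1ccccc1C(=O)Nc1ccc(Sc2nc3ccccc3s2)c(Cl)c1`: in this assay compound 2 gives > 100000 nM, also a limit.
Compound 3, `COc1c(Br)cccc1C(=O)Nc1ccc(Sc2nc3ccccc3s2)c(Cl)c1`: in this assay compound 3 gives > 100000 nM, again a limit.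

All three compounds share one core and differ only in the ring attached to the carbonyl carbon of the amide. Compound 3 stands at the limit of this assay, as do the other two, and the limit of > 100000 nM in this assay, at which 3 of the 3 values shown sit, says as much. None of the three measured steps can be sized: a step that the two limits leave unreadable from compound 1 to compound 2, a step that the two limits leave unreadable from compound 1 to compound 3 and a step that the two limits leave unreadable from compound 2 to compound 3 all fall between two limits.

Compound 4, `O=C(Nc1ccc(Sc2nc3ccccc3s2)c(Cl)c1)c1ccccc1O`, is the next compound. Its change from compound 3 is a group of 7 heavy atoms (6 carbon, 1 oxygen; one six-membered aromatic ring of carbon only) in place of a group of 9 heavy atoms (7 carbon, 1 oxygen, 1 bromine; one six-membered aromatic ring of carbon only), on a carbonyl carbon, so a 2-hydroxyphenyl replaces the ring carrying a methoxy and a bromine. Among the compounds with values here, the only measured steps that bear on such a swap of the amide ring are those among compounds 1, 2 and 3, and each is unreadable. There is thus no ground to expect a readable change, and the expected step is a number no higher from compound 3 to compound 4 (the limit leaves the size open). Compound 4 is expected to give about 100000 nM in this assay, with a likely range from 30000 nM to 300000 nM, and most probably only a limit once more.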

Compound 4, half-maximal inhibitory concentration: > 100000 nM
Compound 4 was reported as a limit (the forecaster's own chance of this, stated with the estimate: 85%); the middle value sits exactly at the limit.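

The steps from compound 4 to compounds 1, 2 and 3 cannot be read, because each one joins two limits and not two numbers: the limit of > 100000 nM in this assay, at which 4 of the 4 values shown sit. As far as these compounds go, how strongly any of these four compounds acts in this assay, and whether changing the ring on the carbonyl carbon alters that at all, stays open.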